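Trading chloro for bromo in a small series

The source may hold more compounds than are shown below. What is called first, only, known or untested is meant among the compounds shown, and "the series" means these compounds.

In a functional assay on B16 cells (Mus musculus) for cytotoxicity, read by CCK-8 assay, with a stated time of 24 h (on this read-out lower numbers stand for stronger inhibition and higher numbers for weaker inhibition), compound 1 `COc1ccccc1Oc1c(N)nc(-c2ccccc2)nc1Cl` gives 4610 nM and compound 2 `COc1ccccc1Oc1c(N)nc(-c2ccc(Cl)cc2)nc1Cl` gives 18800 nM. Compound 2 therefore holds the higher of the two numbers, which means weaker inhibition. The next structure is compound 3 `COc1ccccc1Oc1c(N)nc(-c2ccc(Br)cc2)nc1Cl`, and the change is bromo in place of chloro on an aromatic carbon. Put simply, 4-chlorophenyl turns into 4-bromophenyl. Within the data shown here, only one measured step bears on this. That step, a 4.1-fold higher number from compound 1 to compound 2 (0.61 log units; beyond the scatter), was modest, and it put chloro in place of hydrogen, so it compares chloro with hydrogen and not bromo with chloro. It offers no firm direction for the new change, and no shift beyond the scatter is expected in this assay. The expected size is a 1.0-fold lower number from compound 2 to compound 3 (0.02 log units; within the scatter). For compound 3 the estimated value is 18000 nM, with an expected range from 8000 nM to 40000 nM.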

Compound 3, half-maximal inhibitory concentration: 4440 nM
For compound 3 the middle estimate is 4.1-fold (0.61 log units) above the measured one, outside the stated range (below it).
By their numbers in this assay, from the lowest: compounds 3 and 1 (each within the scatter of the next); then compound 2.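

In this assay the halogen at this spot matters, and the outcome depends on which halogen it is: bromo in place of chloro gives a 4.2-fold lower number from compound 2 to compound 3 (0.63 log units; beyond the scatter) and restores the level of the compound without a halogen. Bromo in place of hydrogen gives a 1.0-fold lower number from compound 1 to compound 3 (0.02 log units; within the scatter) and so leaves no difference beyond the scatter, which means that the weaker inhibition seen with chloro in compound 2 does not carry over to bromo in compound 3. Nothing available explains why these two halogens part ways.

From the compounds shown here alone, how fluoro, a methyl group or an amine at this spot would compare with these three compounds remains open. So does whether the gap between chloro and bromo would persist if the other groups on the shared core were changed.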